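Notes on a chloro step in a limit-bound pair

This account rests on a few compounds, and the source may have more. Where it says the series, first, only, none or still open, it means among the compounds named here.

The series is followed in a functional assay on HCT-116 cells (Homo sapiens) for antiproliferative activity, read by MTT assay, with a stated time of 48 h; a higher number here means a weaker inhibitor, a lower number a stronger inhibitor. Compound 1 `N#CC1=C(N)Oc2c(c3nc4ccccc4nc3c3ccccc23)C12C(=O)N(Cc1cnnn1-c1cc(Cl)ccc1Cl)c1ccccc12` gives only a limit of the assay, > 50000 nM. Compound 2 `N#CC1=C(N)Oc2c(N)cc3nc4ccccc4nc3c2C12C(=O)N(Cc1cnnn1-c1ccccc1Cl)c1ccccc12` likewise gives only a limit, > 50000 nM. Both values shown thus sit at the same limit (the limit of > 50000 nM in this assay, at which 2 of the 2 values shown sit), and compound 2 stands there without a number of its own. Within the data shown here, no measured step between two compounds is available for comparison.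

Compound 3 `N#CC1=C(N)Oc2c(N)cc3nc4ccccc4nc3c2C12C(=O)N(Cc1cnnn1-c1cc(Cl)ccc1Cl)c1ccccc12` is the unmeasured partner of compound 2. It differs by one change (chloro in place of hydrogen on an aromatic carbon); read one bond further out, 2-chlorophenyl becomes 2,5-dichlorophenyl. Compound 1 already carries 2,5-dichlorophenyl and sits at the limit, so nothing here points to a gain. The expected change is a step that the limit leaves unreadable from compound 2 to compound 3, nothing beyond the scatter. Compound 3 is therefore expected to return 60000 nM, between 20000 nM and 200000 nM, most probably as a limit again.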

Compound 3, half-maximal inhibitory concentration: > 50000 nM
Compound 3 was reported as a limit; the forecaster's own chance of this, stated with the estimate: 85%; the middle value is on the limit's open side.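

Compound 2 and compound 3 give no readable step in this assay, as all values shown are limits: the limit of > 50000 nM in this assay, at which 3 of the 3 values shown sit.

The compounds shown leave open whether chloro in place of hydrogen on an aromatic carbon changes activity at all in this assay.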